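The source may report more compounds than this note shows. Statements on the series, on what has been measured and on what is new or still open speak of the compounds shown alone.

Measured compounds in a functional assay on HEK293 cells for antagonist activity at proteinase-activated receptor 4 (Homo sapiens), read by FLIPR and calcium flux, with a stated time of 30 min; on this read-out higher numbers stand for weaker inhibition and lower numbers for stronger inhibition:
- compound 1 `COc1cc(OCc2ccccc2OC)c2cc(-c3cn4nc(OC)sc4n3)oc2c1` gives 19 nM
- compound 2 `CS(=O)(=O)c1nn2cc(-c3cc4ccccc4o3)nc2s1` gives 820 nM
- compound 3 `COc1cc(OCc2cccc(O)c2)c2cc(-c3cn4nc(OC)sc4n3)oc2c1` gives 3.1 nM

Compound 2 stands at the highest number of the three in this assay; its gaps to compound 1 and to compound 3 are both beyond the scatter, so it is the weakest inhibitor measured so far. For the measured compounds named here, the only single-point step measured is a 6.1-fold lower number from compound 1 to compound 3 (0.79 log units; beyond the scatter), and it concerns the benzylic aryl group, a part that compound 2 does not carry. Compound 4 `c1ccc2oc(-c3cn4nc(C5CC5)sc4n3)cc2c1` differs from compound 2 in one place: cyclopropyl in place of methylsulfonyl on an aromatic carbon. Going by the values given here, no measured step bears on this change; compound 1 and compound 3 carry a methoxy at the same position, but they also differ from compound 2 elsewhere, so their lower numbers cannot be attributed to that position alone. The direction of the step is therefore open. On balance compound 4 is expected near 300 nM, with a range from 60 nM to 1500 nM, which means an estimated step of a 2.7-fold lower number from compound 2 to compound 4 (0.44 log units; beyond the scatter) that may or may not exceed the scatter.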

Compound 4, half-maximal inhibitory concentration: 530 nM
Compound 4: middle estimate off by 1.8-fold (0.25 log units), on the low side; measured number inside the range.
By their numbers in this assay, from the lowest: compound 3; then compound 1; then compounds 4 and 2 (each within the scatter of the next).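

In this assay, for the compounds shown here, the first measured change at this position, on an aromatic carbon next to the ring nitrogen and next to the ring sulfur, gives a 1.5-fold lower number from compound 2 to compound 4 (0.19 log units; within the scatter), so methylsulfonyl and cyclopropyl cannot be told apart here. Methylsulfonyl carries 2 hydrogen-bond acceptors and cyclopropyl 0, yet on this core the exchange produces no shift beyond the scatter. No available measurement explains why the two groups read alike.

Going by these compounds, whether a methoxy, an amine or a carboxylic acid at this position on the core of compound 2 would move the number beyond the scatter remains open. Also open, on these data alone, is whether the exchange of methylsulfonyl for cyclopropyl would read the same on the core of compound 1 or compound 3, which also differ elsewhere.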